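A few compounds are considered here, and "the series" means these few. Any claim that something is new, unique, unknown or untested is made for them only; others in the source may bear on it.

Measured compounds in an assay on isolated protein for inhibition of Rho-associated protein kinase 1 (Homo sapiens), read by radiometric assay and 33P incorporation, with a stated time of 40 min, in the presence of a further agent that is not named here; on this read-out lower numbers stand for stronger inhibition and higher numbers for weaker inhibition:
- compound 1 `COc1cccc(Cn2cnc3sc(-c4cccnc4)cc3c2=O)c1` gives > 10000 nM
- compound 2 `COc1cccc(Cn2cnc3sc(-c4ccnc(Cl)c4)cc3c2=O)c1` gives > 10000 nM
- compound 3 `COc1cccc(Cn2cnc3sc(-c4ccnc(C)c4)cc3c2=O)c1` gives 2520 nM

Compound 1 stands only at a limit of this assay, not at a number. Compound 2 likewise sits at a limit. Both share (the limit of > 10000 nM in this assay, at which 2 of the 3 values shown sit), so the step that the two limits leave unreadable from compound 1 to compound 2 cannot be read. Among the compounds with values here, the one numerical value belongs to compound 3, and the steps of an at least 3.9-fold lower number from compound 1 to compound 3 (0.59 log units; beyond the scatter) and an at least 3.9-fold lower number from compound 2 to compound 3 (0.59 log units; beyond the scatter) are both read against a limit and therefore give only a floor for their size.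

Compound 4 `COc1cccc(Cn2cnc3sc(-c4ccnc(N)c4)cc3c2=O)c1` is not yet measured. It differs from compound 1 by 2-aminopyridin-4-yl in place of pyridin-3-yl on an aromatic carbon. Of the measured steps, the one most closely related is the move from compound 1 to compound 3, since both put a substituent in the 2-position of a pyridin-4-yl group; the move from compound 2 to compound 3 shows that the identity of that substituent matters beyond the scatter. Neither step tells how an amino group compares with methyl. The expectation is a lower number than for compound 1, in line with an at least 3.9-fold lower number from compound 1 to compound 3 (0.59 log units; beyond the scatter), and probably a number rather than a limit. For compound 4 the estimate in this assay is 800 nM, with a range from 150 nM to 5000 nM. This estimated step an at least 12-fold lower number from compound 1 to compound 4 (1.09 log units; beyond the scatter) is expected to be at least modest in the direction of stronger inhibition.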

Compound 4, half-maximal inhibitory concentration: 18 nM
For compound 4 the middle estimate is 44-fold (1.65 log units) above the measured one; the whole stated range lies above it.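

In this assay, within the data shown here, the substituent on the pyridin-4-yl group counts for far more than the earlier compounds could show: amino in place of methyl gives a 140-fold lower number from compound 3 to compound 4 (2.15 log units; beyond the scatter), the only new step read between two numbers. Measured against the two compounds at the limit, the change gives an at least 550-fold lower number from compound 1 to compound 4 (2.74 log units; beyond the scatter) and an at least 550-fold lower number from compound 2 to compound 4 (2.74 log units; beyond the scatter), so the aryl group on the carbon next to the ring sulfur can move this series from a limit to a low number, and 2-aminopyridin-4-yl is the group that does so among those shown. These last two steps give only a floor for their size because compound 1 and compound 2 each stand at a limit, not at a number: the limit of > 10000 nM in this assay, at which 2 of the 4 values shown sit.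

As far as these compounds go, whether the gain needs the unsubstituted amino group stays open, and a methylamino, dimethylamino or acetamido group in its place would address that. The unsubstituted pyridin-4-yl group and a 2-aminopyridin-3-yl group would separate the contribution of the ring attachment from that of the amino group, which the change from compound 1 to compound 4 combines.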